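A few compounds are considered here, and "the series" means these few. Any claim that something is new, unique, unknown or untested is made for them only; others in the source may bear on it.

Measured so far in a physicochemical assay for solubility, in phosphate buffer, measured as kinetic solubility, with a stated time of 1 h, at pH 7.4; a higher number here means a more soluble compound, a lower number a less soluble compound:

- compound 1 (`CNCC(=O)Nc1ccc(-c2nc(CS(C)(=O)=O)cc([C@@]34CCOC[C@@H]3C4)n2)cc1`): 167 ug/mL
- compound 2 (`CNCC(=O)Nc1ccc(-c2nc(C(C)(C)S(C)(=O)=O)cc([C@]34CCOC[C@H]3C4)n2)cc1`): 217 ug/mL

Only these two compounds have been measured, so the series offers little to go on. Compound 2 at 217 ug/mL and compound 1 at 167 ug/mL lie within the scatter of each other, so the two values do not separate them. Going by the values given here, they also differ in more than one place, and no clean single-change step is available from the data.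

The next compound, compound 3 (`CNCC(=O)Nc1ccc(-c2nc(C(C)(C)S(C)(=O)=O)cc([C@@]34CCOC[C@@H]3C4)n2)cc1`), is related to compound 2 by the two compounds have the same atoms and bonds and differ only in configuration as drawn: 2 of 2 stereo elements differ (all stereocentres are inverted: mirror images); a stereocentre at a saturated ring carbon is drawn R in compound 2 and S in compound 3; a stereocentre at a saturated ring carbon is drawn S in compound 2 and R in compound 3. The atoms and bonds are the same, and the two compounds are mirror images. Among the compounds with values here, no measured pair of mirror images exists to calibrate the change, so the expectation rests on compound 2 at 217 ug/mL. No change beyond the scatter is expected in this assay, and no direction is favoured. The estimated size of the step is a 1.0-fold lower number from compound 2 to compound 3 (0.00 log units; within the scatter). For compound 3 the expected value is 215 ug/mL, with an estimated range of 150 ug/mL to 300 ug/mL.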

Compound 3, solubility: 257 ug/mL
The estimate for compound 3 lay 1.2-fold (0.08 log units) below the measured number; measured number inside the range.
By their numbers in this assay, from the lowest: compounds 1, 2 and 3 (each within the scatter of the next).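

In this assay the mirror-image pair gives the series its first reading of configuration, with a 1.2-fold higher number from compound 2 to compound 3 (0.07 log units; within the scatter) as the printed step, so inverting both stereocentres does not separate these two compounds here. Going by these compounds alone, the same result provides the first single-place step at the aromatic carbon: 1-methyl-1-(methylsulfonyl)ethyl in place of (methylsulfonyl)methyl gives a 1.5-fold higher number from compound 1 to compound 3 (0.19 log units; within the scatter) and thus, in this configuration, a difference that also stays inside the usual scatter. The mirror-image comparison is a clean test of configuration alone, with no second structural difference to weigh against it: the fact that compounds 2 and 3 differ only in the configuration as drawn.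

Still open is whether the configuration result carries over to the (methylsulfonyl)methyl compound, since the mirror image of compound 1 is not among the compounds shown, and the single pair cannot support a general rule for the series. Also open is how this assay responds to a larger change at the same aromatic carbon, such as an amine or a carboxylic acid in place of the sulfone-bearing group, as every compound shown carries a methylsulfonyl group there.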